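Replacing carbamoyl with methyl: compound 1 to compound 3

A few compounds are considered here, and "the series" means these few. Any claim that something is new, unique, unknown or untested is made for them only; others in the source may bear on it.

Compound 1 `COc1cc(OC)cc(C(=CC(N)=O)c2ccc(OC)c(OC)c2)c1` has no measured number: in a functional assay on HCT-116 cells (Homo sapiens) for cytotoxicity, read by scintillation counting and thymidine incorporation, with a stated time of 72 h (a lower number here means a stronger inhibitor, a higher number a weaker inhibitor), compound 1 gives > 10000 nM, which is a limit of the assay. Going by the values given here, the only numeric value comes from compound 2 `C=C(c1ccc(OC)c(N)c1)c1ccc(OC)c(OCC)c1`, which gives 38 nM and carries no carbamoyl. Compound 3 `CC=C(c1cc(OC)cc(OC)c1)c1ccc(OC)c(OC)c1` differs from compound 1 by methyl in place of carbamoyl on a double-bonded chain carbon bound to a double-bonded chain carbon. In this assay a step towards stronger inhibition is expected, estimated as an at least 6.6-fold lower number from compound 1 to compound 3 (0.82 log units; beyond the scatter). The estimate for compound 3 is 1500 nM, with an expected range of 150 nM to 10000 nM.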

Compound 3, half-maximal inhibitory concentration: 480 nM
The estimate for compound 3 lay 3.1-fold (0.49 log units) above the measured number; the range from low to high includes it.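

In this assay, going by these compounds alone, methyl in place of carbamoyl on a double-bonded chain carbon bound to a double-bonded chain carbon gives the first readable step at this place: an at least 20-fold lower number from compound 1 to compound 3 (1.31 log units; beyond the scatter). Compound 1 gives > 10000 nM, which is a limit of the assay. The step therefore gives only a minimum size, and its full size stays unknown: the limit of > 10000 nM in this assay, at which 1 of the 3 values shown sits.

On these data alone, whether an ethyl chain, an aminomethyl group or a carboxylic acid at this place would read like methyl or like carbamoyl stays open. Compound 2 differs from compound 3 in more than one place and offers no comparison for this change.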